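The compounds below may be only part of what the source reports. "The series", "measured", "known", "first", "only" and "open" are said of these compounds alone.

Compound 2 `N#CC1=C(N)N(c2ccc(S(N)(=O)=O)cc2)C2=C(C(=O)CCC2)C1c1ccco1` and compound 1 `COc1ccccc1C1C(C#N)=C(N)N(c2ccc(S(N)(=O)=O)cc2)C2=C1C(=O)CCC2` share one core and differ only in the group carried on a saturated ring carbon. In a functional assay on Ehrlich cells (Mus musculus) for antiproliferative activity, read by trypan blue exclusion, with a stated time of 2 h, tested at 50 ug/mL (a higher number here means a stronger effect of the compound at the concentration tested, a lower number a weaker effect), compound 1 gives 0%, and compound 2 gives 5%. Compound 2 thus stands with compound 1 at the bottom of the scale, the two separated only by a number 5 percentage points higher from compound 1 to compound 2 (within the scatter), a gap within the scatter. Compound 3 `Cc1ccoc1C1C(C#N)=C(N)N(c2ccc(S(N)(=O)=O)cc2)C2=C1C(=O)CCC2` keeps the furan of compound 2 and adds one small group: methyl in place of hydrogen on an aromatic carbon. Among the measured compounds shown here, no measured step alters a furan in this way; the only step known, a number 5 percentage points higher from compound 1 to compound 2 (within the scatter), exchanged the whole group on the saturated ring carbon and still left both compounds showing almost no effect. A step of no change at the digits printed from compound 2 to compound 3 (within the scatter) is therefore expected, nothing beyond the scatter. Compound 3 is estimated to give 5% in this assay, most likely between 0% and 20%.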

Compound 3, a percentage reported as activity, at one concentration (the size of the read-out at that concentration, not a potency): 40%
Compound 3: the middle estimate sits 35 percentage points below what was measured, and the stated range ends below it.
By their numbers in this assay, from the lowest: compounds 1 and 2 (each within the scatter of the next); then compound 3.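

In this assay a single methyl on the furan brings a number 35 percentage points higher from compound 2 to compound 3 (beyond the scatter), so this position, on an aromatic carbon next to the ring atom that bears a large group, responds strongly to a very small addition, something the earlier pair could not show. Compound 1 and compound 2 lie within the scatter of each other, yet 3-methylfuran-2-yl in place of 2-methoxyphenyl gives a number 40 percentage points higher from compound 1 to compound 3 (beyond the scatter), so among these compounds a furan alone is not enough and the methyl on it makes the difference. Nothing available here explains why this methyl has such an effect.

Going by these compounds, whether an ethyl group, a methoxy group or a chlorine atom on the same furan carbon would keep this gain remains open. So does the outcome of moving the methyl to another carbon of the furan.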